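This account rests on a few compounds, and the source may have more. Where it says the series, first, only, none or still open, it means among the compounds named here.

Of the compounds shown here, three sharing one core have been measured in an assay for binding affinity to metabotropic glutamate receptor 5 (Rattus norvegicus); on this read-out higher numbers stand for weaker inhibition and lower numbers for stronger inhibition. Among the compounds with values here, compound 1 `Cc1c[nH]c(-c2nnn(-c3cc(F)cc(C#N)c3)n2)n1` gives 19 nM, and compound 2 `N#Cc1cc(F)cc(-n2nnc(-c3ncc[nH]3)n2)c1` gives 9.3 nM; the single one-place step between them, a 2.0-fold lower number from compound 1 to compound 2 (0.31 log units; beyond the scatter), is a modest one. Compound 3 `N#Cc1cccc(-n2nnc(-c3nccs3)n2)c1` gives 183 nM, the highest of the three numbers and beyond the scatter from both others, so it is the weakest binder of the set.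

Compound 4 `N#Cc1cccc(-n2nnc(-c3cc[nH]n3)n2)c1` differs from compound 3 by 1H-pyrazol-3-yl in place of 1,3-thiazol-2-yl on an aromatic carbon. Within the data shown here, the one measured step, the methyl-to-hydrogen change of a 2.0-fold lower number from compound 1 to compound 2 (0.31 log units; beyond the scatter), lies elsewhere in the molecule and gives no direct guide. What the numbers do show is that compounds 1 and 2, whose five-membered heteroaryl carries a ring nitrogen bearing hydrogen, as the entering pyrazolyl does, sit far below compound 3; they also carry a fluorine that compound 3 lacks, so the comparison is not a clean one. A move toward lower numbers is nonetheless expected. Compound 4 is estimated at 40 nM, with a likely range from 10 nM to 160 nM. This corresponds to an expected step of a 4.6-fold lower number from compound 3 to compound 4 (0.66 log units; beyond the scatter).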

Compound 4, inhibition constant: > 2000 nM
Compound 4 gave a limit, no number; the forecaster's own chance of this, stated with the estimate: 2%; middle value at least 50-fold (1.69 log units) away from the limit.
By their numbers in this assay, from the lowest: compound 2; then compound 1; then compound 3. At a limit, above all of these: compound 4.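

Within the data shown here, this carbon of the shared core, on the five-membered aromatic ring with 4 nitrogen, proves highly sensitive to which ring it carries, something the one earlier step, a change elsewhere in the molecule, could not show. Exchanging 1,3-thiazol-2-yl for 1H-pyrazol-3-yl keeps the ring size and the number of heavy atoms, yet in this assay it gives an at least 10-fold higher number from compound 3 to compound 4 (1.03 log units; beyond the scatter) and so a large loss of binding. Compound 4 gave a limit of the assay and not a number: the limit of > 2000 nM in this assay, at which 1 of the 4 values shown sits.

From the compounds shown here alone, what stays open is whether this loss goes with the hydrogen-bond donor that 1H-pyrazol-3-yl brings or with the arrangement of its ring atoms. A 1-methylpyrazolyl or an oxazolyl group on this same carbon would help to separate the two.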